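The source may hold more compounds than are shown below. What is called first, only, known or untested is meant among the compounds shown, and "the series" means these compounds.

Of the compounds shown here, three of a shared core have been tested in a functional assay on HeLa cells (Homo sapiens) for inhibition, read by sulforhodamine B assay; on this read-out higher numbers stand for weaker inhibition and lower numbers for stronger inhibition. Compound 1 `COc1cccc(NC2=CC(=O)c3nc4n(c3C2=O)[C@H]2OC[C@@H](O)[C@H]2OC4)c1` gives 4280 nM, and compound 3 `COc1ccc(NC2=CC(=O)c3nc4n(c3C2=O)[C@H]2OC[C@@H](O)[C@H]2OC4)cc1` gives 4780 nM. Within the data shown here, the only one-place comparison among them, a 1.1-fold higher number from compound 1 to compound 3 (0.05 log units; within the scatter), shows that swapping 4-methoxyphenyl for 3-methoxyphenyl on the amine nitrogen changes little. Compound 2 `O=C1C(NC2CCCC2)=CC(=O)c2c1nc1n2[C@H]2OC[C@@H](O)[C@H]2OC1` is different: in this assay it reaches only a limit, > 16000 nM, so no number is known for it; it sits at the limit of > 16000 nM in this assay, at which 1 of the 3 values shown sits, the weakest end of what the assay can report. Compound 4 `CCc1ccc(NC2=CC(=O)c3c(nc4n3[C@H]3OC[C@@H](O)[C@H]3OC4)C2=O)cc1` is the new member, and relative to compound 2 it carries 4-ethylphenyl in place of cyclopentyl on an amine nitrogen. Among the measured compounds shown here, no measured step covers an exchange of cyclopentyl for an aryl group, so the expectation rests only on where the two aryl compounds stand against compound 2. Compound 4 is therefore expected to land near compound 1 and compound 3, a step of an at least 3.5-fold lower number from compound 2 to compound 4 (0.55 log units; beyond the scatter) toward stronger inhibition. The estimate for compound 4 is 4500 nM, within 1500 nM to 16000 nM.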

Compound 4, half-maximal inhibitory concentration: 6510 nM
The estimate for compound 4 lay 1.4-fold (0.16 log units) below the measured number, and the stated range covers the measured number.
By their numbers in this assay, from the lowest: compounds 1, 3 and 4 (each within the scatter of the next). At a limit, above all of these: compound 2.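

In this assay, exchanging cyclopentyl for 4-ethylphenyl on the amine nitrogen gives an at least 2.4-fold lower number from compound 2 to compound 4 (0.39 log units; beyond the scatter), so this change has a real effect on the number, although only the smallest possible size of the step is known. The entry for compound 2 is a limit and not a number: the limit of > 16000 nM in this assay, at which 1 of the 4 values shown sits.

The new aryl group also extends the earlier picture, as compound 3 gives 4780 nM and compound 4 gives 6510 nM, two values within the scatter of each other.

Still open, going by these compounds, is how a cyclohexyl group on this nitrogen would compare with 4-ethylphenyl, a comparison that would help separate the effect of an aromatic ring from that of ring size. Also open, on these data alone, is whether an amine or a carboxylic acid on the phenyl ring would move the number beyond the scatter.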